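From piperidin-1-yl to diethylamino in compound 4

The compounds below may be only part of what the source reports. "The series", "measured", "known", "first", "only" and "open" are said of these compounds alone.

In a functional assay on A549 cells (Homo sapiens) for inhibition (on this read-out lower numbers stand for stronger inhibition and higher numbers for weaker inhibition), compound 3 (`CCN(C(=O)CC(CC(=O)NCCN1CCCCC1)c1ccc(Cl)cc1)C1Cc2ccccc2C1`) gives 13200 nM, the lowest of the three numbers measured. Compound 1 (`O=C(CC(CC(=O)NC1Cc2ccccc2C1)c1ccc(Cl)cc1)NCCN1CCCCC1`) gives 28000 nM, and compound 2 (`CCN(CC)CCNC(=O)CC(CC(=O)NC1Cc2ccccc2C1)c1ccc(Cl)cc1`) gives 48600 nM. Compound 4 (`CCN(CC)CCNC(=O)CC(CC(=O)N(CC)C1Cc2ccccc2C1)c1ccc(Cl)cc1`) is not yet measured and differs from compound 3 as follows: diethylamino in place of piperidin-1-yl on a saturated chain carbon, two bonds along the chain from an amide-type nitrogen. The same exchange has been measured once, as a 1.7-fold higher number from compound 1 to compound 2 (0.24 log units; within the scatter). The other step, a 2.1-fold lower number from compound 1 to compound 3 (0.33 log units; beyond the scatter), is ethyl in place of hydrogen on an amide-type nitrogen; that ethyl stays in place here, so it sets only the starting level. In this assay a small rise is therefore expected, with the estimated step being a 1.5-fold higher number from compound 3 to compound 4 (0.18 log units; within the scatter). Compound 4 is expected at 20000 nM, with an estimated range from 10000 nM to 42000 nM.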

Compound 4, half-maximal inhibitory concentration: 18400 nM
For compound 4 the middle estimate is 1.1-fold (0.04 log units) above the measured one; the measured number falls inside the stated range.
By their numbers in this assay, from the lowest: compounds 3, 4, 1 and 2 (each within the scatter of the next, the first and the last beyond it).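

In this assay, diethylamino in place of piperidin-1-yl gives a 1.4-fold higher number from compound 3 to compound 4 (0.14 log units; within the scatter), so with ethyl on the amide-type nitrogen this exchange stays within the scatter, as it did with hydrogen there: the same change on two cores in this assay, a 1.7-fold higher number (0.24 log units; within the scatter) from compound 1 to compound 2 and a 1.4-fold higher number (0.14 log units; within the scatter) from compound 3 to compound 4, 1.2-fold (0.10 log units) apart, within the scatter of two such steps. Ethyl in place of hydrogen on an amide-type nitrogen, earlier read on one core only, gives a 2.6-fold lower number from compound 2 to compound 4 (0.42 log units; beyond the scatter) and so also holds with diethylamino: the same change on two cores in this assay, a 2.1-fold lower number (0.33 log units; beyond the scatter) from compound 1 to compound 3 and a 2.6-fold lower number (0.42 log units; beyond the scatter) from compound 2 to compound 4, 1.2-fold (0.10 log units) apart, within the scatter of two such steps. Across these four compounds, the two changes add up without visibly affecting each other.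

Going by these compounds, it remains open whether morpholin-4-yl in place of piperidin-1-yl, or a longer chain to the amine, would move the number beyond the scatter. On these data alone, it is also open whether propyl on the amide-type nitrogen would extend the step seen with ethyl.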